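The compounds below may be only part of what the source reports. "The series", "measured", "known", "first", "only" and "open" are said of these compounds alone.

In a functional assay on CWR22R cells (Homo sapiens) for antiproliferative activity, read by propidium iodide staining, with a stated time of 96 h (on this read-out lower numbers stand for stronger inhibition and higher numbers for weaker inhibition), three compounds have been measured. Compound 1 `CC(O)(COc1cc(C(F)(F)F)cc(C(F)(F)F)c1)C(=O)Nc1cccc(S(F)(F)(F)(F)F)c1` gives 6500 nM. Compound 2 `CC(O)(COc1cccc(S(F)(F)(F)(F)F)c1)C(=O)Nc1cc(C(F)(F)F)cc(C(F)(F)F)c1` gives 2300 nM. Compound 3 `CC(O)(COc1cccc(C(F)(F)C(F)(F)F)c1)C(=O)Nc1cc(C(F)(F)F)cc(C(F)(F)F)c1` gives 4100 nM.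

Compound 1 and compound 2 are built from the same atoms joined differently; the difference between the two cores is not broken down here. Compound 3 comes from compound 2 through one change, (a group of 7 heavy atoms (2 carbon, 5 fluorine; no ring) in place of a group of 6 heavy atoms (5 fluorine, 1 sulfur; no ring), on an aromatic carbon), and that step is a 1.8-fold higher number from compound 2 to compound 3 (0.25 log units; within the scatter). Compound 4 `CC(O)(COc1cc(C(F)(F)F)cc(C(F)(F)F)c1)C(=O)Nc1cccc(C(F)(F)C(F)(F)F)c1` comes from compound 1 through the same change, (a group of 7 heavy atoms (2 carbon, 5 fluorine; no ring) in place of a group of 6 heavy atoms (5 fluorine, 1 sulfur; no ring), on an aromatic carbon), at a place described in the same words. The expected step from compound 1 to compound 4 in this assay is therefore a 1.7-fold higher number from compound 1 to compound 4 (0.23 log units; within the scatter). This expectation rests on the step of a 1.8-fold higher number from compound 2 to compound 3 (0.25 log units; within the scatter) applied to the value of compound 1, 6500 nM. Compound 4 is expected to give 11000 nM, with a likely range from 4500 nM to 28000 nM.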

Compound 4, half-maximal inhibitory concentration: 4500 nM
Beside the measured number, compound 4's estimate is 2.4-fold (0.39 log units) above it; the measured number falls inside the stated range.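

In this assay the change to 1,1,2,2,2-pentafluoroethyl gives a 1.4-fold lower number from compound 1 to compound 4 (0.16 log units; within the scatter), so on the core of compound 1 the swap makes no clear difference. The earlier step on the other core looks much the same once ordinary scatter is allowed for: the same change on two cores in this assay, a 1.8-fold higher number (0.25 log units; within the scatter) from compound 2 to compound 3 and a 1.4-fold lower number (0.16 log units; within the scatter) from compound 1 to compound 4, 2.6-fold (0.41 log units) apart, within the scatter of two such steps. This shows that the change made no clear difference on either of these two cores, but two small steps cannot show that the same holds on any other core.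

The compounds shown leave open whether other groups in this place, such as an amine, a carboxylic acid or a longer fluorinated chain, would give clearly different numbers. They also leave open how the change behaves on cores outside this small set.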